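Solubility notes: aryl substituent change on compound 2

This account rests on a few compounds, and the source may have more. Where it says the series, first, only, none or still open, it means among the compounds named here.

Measured so far in a physicochemical assay for solubility, in phosphate buffer, at pH 7.4; on this read-out lower numbers stand for lower solubility and higher numbers for higher solubility:
compound 1, `CCOC(=O)c1c(-c2cccc(C(F)(F)F)c2)[nH]c2cc(OC)ccc2c1=O`, 19000 nM
compound 2, `CCOC(=O)c1c(-c2cccc([N+](=O)[O-])c2)[nH]c2cccc(OC)c2c1=O`, 49000 nM
compound 3, `CCOC(=O)c1c(-c2ccc(C(C)(C)C)cc2)[nH]c2cc(OC)ccc2c1=O`, 2000 nM

Compound 2 stands highest of the three numbers in this assay. Its nearest neighbour on the read-out is compound 1, whose value sits below it by more than the usual scatter; compound 3 lies furthest, well below it and also beyond the scatter. Among the measured compounds shown here, none of the three pairs differs in only one place, so no single-point step is available from the measured set, and the spread across the three can only be read as what the values show.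

Compound 4, `CCOC(=O)c1c(-c2cccc(OC)c2)[nH]c2cccc(OC)c2c1=O`, is not yet measured in this assay. It differs from compound 2 as follows: methoxy in place of nitro on an aromatic carbon.

For the measured compounds named here, with no measured step of this kind to lean on, the expectation rests on the value of compound 2, 49000 nM, as the anchor. The step from compound 2 to compound 4 is expected to be modest and, if anything, toward a lower number, a 1.6-fold lower number from compound 2 to compound 4 (0.21 log units; within the scatter), not clearly beyond the scatter. Compound 4 is therefore estimated at 30000 nM in this assay, with a likely range from 10000 nM to 80000 nM.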

Compound 4, solubility: > 100000 nM
Compound 4 ended at the assay's limit; the forecaster's own chance of this, stated with the estimate: 5%; at least 3.3-fold (0.52 log units) between middle value and limit.
By their numbers in this assay, from the lowest: compound 3; then compound 1; then compound 2. At a limit, above all of these: compound 4.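

In this assay, among the compounds shown here, the only one-place step is 3-nitrophenyl to 3-methoxyphenyl, and it reads an at least 2.0-fold higher number from compound 2 to compound 4 (0.30 log units; that floor lies within the scatter). Compound 4 stands at a limit of this assay, > 100000 nM, and this entry is a limit, not a number. At this aromatic carbon, then, methoxy in place of nitro gives no sign of a lower number, though the true size of the step cannot be stated and its printed floor does not by itself clear the scatter, because the read-out ends there: the limit of > 100000 nM in this assay, at which 1 of the 4 values shown sits.

The compounds shown leave open whether this result is specific to methoxy, or whether another group on the same carbon, such as an amine or a carboxylic acid, would also keep the core of compound 2 at or near the limit. As far as these compounds go, compound 1 and compound 3 each differ from compound 2 in more than one place, so whether the same change would hold on the core of compound 1 or compound 3 also remains open.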